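The compounds below may be only part of what the source reports. "The series", "measured", "known", "first", "only" and "open" are said of these compounds alone.

Compound 1 `C=Cc1c(CCC)nn(CCCN2CCN(c3ccc(C)cc3)CC2)c(=O)c1N` gives 7% in a functional assay on the whole organism (Abdomen, strain Swiss) for inhibition, with Mus musculus as the target, with stated times of 30 min, 10 min and 5 min, at a dose of 20 mg/kg by the oral route; a lower number here means a weaker effect, a higher number a stronger effect of the compound at the dose given. Compound 2 `C=Cc1c(CCCC)nn(CCCN2CCN(c3ccc(C)cc3)CC2)c(=O)c1N` gives 41% in this assay, and the change methyl in place of hydrogen on a saturated chain carbon, three bonds along the chain from an aromatic carbon made the step of a number 34 percentage points higher from compound 1 to compound 2 (beyond the scatter). Compound 3 `CC/C=C/c1c(C)nn(CCCN2CCN(c3ccc(C)cc3)CC2)c(=O)c1N` has the same atoms as compound 1 joined differently; the difference between the two cores is not broken down here. In this assay compound 3 gives 35%, a value within the scatter of compound 2. Compound 4 `CCC/C=C/c1c(C)nn(CCCN2CCN(c3ccc(C)cc3)CC2)c(=O)c1N` differs from compound 3 by methyl in place of hydrogen on a saturated chain carbon, two bonds along the chain from a double-bonded chain carbon. This is the same kind of change as that from compound 1 to compound 2, but not the same: there the methyl enters three bonds along the chain from an aromatic carbon, here two bonds along the chain from a double-bonded chain carbon. Because a number 34 percentage points higher from compound 1 to compound 2 (beyond the scatter) is large, a gain is also expected here. The step expected is a number 10 percentage points higher from compound 3 to compound 4 (within the scatter), smaller than the earlier one, resting on that single precedent. Compound 4 is therefore estimated at 45%, between 20% and 70%.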

Compound 4, a percentage reported as inhibition, in the whole organism at one dose (the size of the read-out at that dose, not a potency): 16%
Compound 4: middle estimate off by 29 percentage points, on the high side, outside the stated range (below it).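

In this assay the methyl in place of hydrogen gave a number 19 percentage points lower from compound 3 to compound 4 (beyond the scatter) and, set beside the earlier pair, the same change did not carry over from one core to the other: the same change on two cores in this assay, a number 34 percentage points higher (beyond the scatter) from compound 1 to compound 2 and a number 19 percentage points lower (beyond the scatter) from compound 3 to compound 4, 53 percentage points apart, beyond the scatter of two such steps.

The two pairs differ in the place of the methyl as well as in the core: three bonds along the chain from an aromatic carbon in one, two bonds along the chain from a double-bonded chain carbon in the other. They therefore do not show which of these differences decides the direction of the step, and two pairs give no rule for any further core.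

On these data alone, what a chain longer than pent-1-en-1-yl, or an amine or a carboxylic acid at the end of the chain, would give in this assay remains open.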